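From fluoro to heptyl on a saturated chain carbon

The source may report more compounds than this note shows. Statements on the series, on what has been measured and on what is new or still open speak of the compounds shown alone.

Measured in a functional assay on HeLa cells (Homo sapiens) for cytotoxicity, read by WST assay, with a stated time of 48 h; a higher number here means a weaker inhibitor, a lower number a stronger inhibitor:
- compound 1 `COC[C@H](C(C)C)C(c1ccc(O)c(OC)c1)c1ccc(O)c(OC)c1` gives 76000 nM
- compound 2 `COc1cc(C(c2ccc(O)c(OC)c2)[C@H](C)C(C)C)ccc1O` gives 16000 nM
- compound 3 `COc1cc(C(c2ccc(O)c(OC)c2)[C@H](CF)C(C)C)ccc1O` gives 19000 nM

Compound 3 sits level with compound 2 and well under compound 1 on these numbers. The next structure, compound 4 (`CCCCCCCC[C@H](C(C)C)C(c1ccc(O)c(OC)c1)c1ccc(O)c(OC)c1`), has heptyl in place of fluoro on a saturated chain carbon, three bonds along the chain from two aromatic carbons. Going by the values given here, three measured steps bear on this place. Two are modest, a 4.8-fold lower number from compound 1 to compound 2 (0.68 log units; beyond the scatter) and a 4.0-fold lower number from compound 1 to compound 3 (0.60 log units; beyond the scatter), while a 1.2-fold higher number from compound 2 to compound 3 (0.07 log units; within the scatter) is small. None involves a chain this long, so the direction is uncertain. In this assay the estimated step is small, a 1.6-fold lower number from compound 3 to compound 4 (0.20 log units; within the scatter), with no clear shift expected. For compound 4 the expected value is 12000 nM (3000 nM to 40000 nM).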

Compound 4, half-maximal inhibitory concentration: 3100 nM
Compound 4: middle estimate off by 3.9-fold (0.59 log units), on the high side; measured number inside the range.
By their numbers in this assay, from the lowest: compound 4; then compounds 2 and 3 (each within the scatter of the next); then compound 1.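

Going by these compounds alone, at this position on a saturated chain carbon, heptyl brings the lowest number so far in this assay, with a 6.1-fold lower number from compound 3 to compound 4 (0.79 log units; beyond the scatter) and a 5.2-fold lower number from compound 2 to compound 4 (0.71 log units; beyond the scatter), whereas fluoro and hydrogen stayed within the scatter of each other. Set against methoxy, the change is the largest here, a 25-fold lower number from compound 1 to compound 4 (1.39 log units; beyond the scatter). So this position can respond to a long carbon chain, which the small replacements could not reveal.

Going by these compounds, whether a butyl chain, a longer chain such as dodecyl, or a heptyl chain ending in an amine would go lower stays open. Nothing measured here gives a reason for the shift.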